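The source may report more compounds than this note shows. Statements on the series, on what has been measured and on what is new or still open speak of the compounds shown alone.

Among the compounds with values here, compound 1 `C[C@H](NC(=O)CN(c1nc(Cl)nc2c1ncn2C1CCCCO1)C1CC1)C(=O)OCc1ccccc1` gives 32.1% in a functional assay on the whole organism with Mus musculus as the target, with a stated time of 90 min, at a dose of 25 umol/kg by the oral route (a higher number here means a stronger effect of the compound at the dose given, a lower number a weaker effect), the second highest of the three numbers measured so far. Compound 2 `CC[C@H](C)[C@H](NC(=O)CN(c1nc(Cl)nc2c1ncn2C1CCCCO1)C1CC1)C(=O)OCc1ccccc1` gives 22.6% in this assay, and compound 3 `CSCC[C@H](NC(=O)CN(c1nc(Cl)nc2c1ncn2C1CCCCO1)C1CC1)C(=O)OCc1ccccc1` gives 42.7% in this assay. Compound 4 `C[C@@H](O)[C@H](NC(=O)CN(c1nc(Cl)nc2c1ncn2C1CCCCO1)C1CC1)C(=O)OCc1ccccc1` differs from compound 1 by 1-hydroxyethyl in place of methyl on a saturated chain carbon bound to an amide-type nitrogen and a carbonyl carbon. Two measured steps alter the same saturated chain carbon: a number 9.5 percentage points lower from compound 1 to compound 2 (within the scatter), and a number 20.1 percentage points higher from compound 2 to compound 3 (beyond the scatter). A third step is also known: a number 10.6 percentage points higher from compound 1 to compound 3 (beyond the scatter). None of them brings in a hydroxyl, so they indicate only the modest size of steps seen at this position, not a direction. Compound 4 is therefore expected to show a step of a number 2.9 percentage points higher from compound 1 to compound 4 (within the scatter). Compound 4 is estimated at 35%, with a range from 15% to 55%.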

Compound 4, a percentage reported as activity, at one dose (the size of the read-out at that dose, not a potency): 23.4%
For compound 4 the middle estimate is 11.6 percentage points above the measured one; measured number inside the range.
By their numbers in this assay, from the lowest: compounds 2, 4 and 1 (each within the scatter of the next); then compound 3.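

In this assay, the 1-hydroxyethyl group brings the first hydroxyl to this saturated chain carbon, and the number stays within the scatter of the methyl compound (a number 8.7 percentage points lower from compound 1 to compound 4 (within the scatter)) and the sec-butyl compound (a number 0.8 percentage points higher from compound 2 to compound 4 (within the scatter)). Only the 2-(methylsulfanyl)ethyl group stands clearly apart (a number 19.3 percentage points lower from compound 3 to compound 4 (beyond the scatter)). No measurement given here accounts for these differences. Still open, on these data alone, is how an amine or a carboxylic acid on this carbon would read, and whether a longer chain carrying the hydroxyl would stay level with 1-hydroxyethyl.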